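Swapping One Heteroaryl Group for Another on Compound 2

The source may report more compounds than this note shows. Statements on the series, on what has been measured and on what is new or still open speak of the compounds shown alone.

compound 1, `Cc1cccnc1-c1ccccc1OCC1=NCCN1`: < 100000 nM
compound 2, `c1ccc(-c2ccncn2)c(OCC2=NCCN2)c1`: < 100000 nM

Of the compounds shown here, two have been measured in a functional assay for activation of Alpha-1A adrenergic receptor (Homo sapiens), read by calcium flux; a higher number here means that more compound is needed for the effect, a lower number that less compound is needed. Compound 1 `Cc1cccnc1-c1ccccc1OCC1=NCCN1` shows only a limit of the assay, < 100000 nM. Compound 2 `c1ccc(-c2ccncn2)c(OCC2=NCCN2)c1` likewise gives only a limit, < 100000 nM. Both stand at the limit of < 100000 nM in this assay, at which 2 of the 2 values shown sit. Compound 3 `c1ccc(-c2ccns2)c(OCC2=NCCN2)c1` differs from compound 2 by 1,2-thiazol-5-yl in place of pyrimidin-4-yl on an aromatic carbon, in words 1,2-thiazol-5-yl in place of pyrimidin-4-yl on an aromatic carbon. Among the measured compounds shown here, no step between measured compounds is known, and neither measured compound gives more than a limit, so no step beyond the usual scatter is expected, the expected step being a step that the limit leaves unreadable from compound 2 to compound 3. Compound 3 is estimated at 5000 nM, between 500 nM and 50000 nM.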

Compound 3, half-maximal effective concentration: 5.01 nM
The estimate for compound 3 lay 1000-fold (3.00 log units) above the measured number; the whole stated range lies above it.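

No step from compound 2 to compound 3 can be read, since compound 2 gives only a limit of the assay: the limit of < 100000 nM in this assay, at which 2 of the 3 values shown sit.

The compounds shown leave open how large the effect of 1,2-thiazol-5-yl in place of pyrimidin-4-yl actually is.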